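Three Limits and a Dinitrophenyl Substitution

This account rests on a few compounds, and the source may have more. Where it says the series, first, only, none or still open, it means among the compounds named here.

Three compounds built on a shared core have been examined in an ADME assay on HEK-293T cells (Homo sapiens) for cytotoxicity, read by CCK-8 assay, with a stated time of 48 h; a lower number here means a stronger inhibitor, a higher number a weaker inhibitor. Compound 1 `Nc1ccc(Oc2ccccc2-c2ccc(S(=O)(=O)NCCNC(=O)Nc3ccc(Cl)cc3)s2)cc1` returns only a limit there, > 20000 nM. Compound 2 `O=S(=O)(c1sccc1-c1ccccc1Oc1ccc(O)c(O)c1)N1CCN(C(=S)Nc2cc(C(F)(F)F)cc(C(F)(F)F)c2)CC1` likewise returns only a limit in this assay, > 20000 nM. Compound 3 `COc1ccc(Oc2ccccc2-c2ccsc2S(=O)(=O)N2CCN(C(=S)Nc3ccc([N+](=O)[O-])cc3)CC2)cc1OC` also stops at a limit in this assay, > 20000 nM. Among the measured compounds shown here, compound 1 thus stands where every measured compound stands, at the limit of > 20000 nM in this assay, at which 3 of the 3 values shown sit, so the three cannot be ordered against one another, and no step between two measured compounds is available.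

Compound 4 `O=C(NCCNS(=O)(=O)c1ccc(-c2ccccc2Oc2ccc([N+](=O)[O-])c([N+](=O)[O-])c2)s1)Nc1ccc(Cl)cc1` differs from compound 1 by 3,4-dinitrophenyl in place of 4-aminophenyl on an oxygen on an aromatic ring; the 4-aminophenyl leaves and a 3,4-dinitrophenyl enters. The step from compound 1 to compound 4 is expected to be a step that the limit leaves unreadable from compound 1 to compound 4, that is, none beyond the scatter, because all three measured values sit at the limit of > 20000 nM in this assay, at which 3 of the 3 values shown sit. Compound 4 is therefore expected to give 30000 nM in this assay, within a range from 10000 nM to 100000 nM, and most probably to be reported only as a limit again.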

Compound 4, half-maximal inhibitory concentration: > 20000 nM
Compound 4 ended at the assay's limit; the forecaster's own chance of this, stated with the estimate: 80%; the middle value is on the limit's open side.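

Compound 4 gives > 20000 nM in this assay, which is a limit and not a number, so no step from compound 1 to compound 4 can be read: the limit of > 20000 nM in this assay, at which 4 of the 4 values shown sit.

The compounds shown leave open where any of the four would truly fall in this assay, and whether 3,4-dinitrophenyl in place of 4-aminophenyl changes that position at all.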